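Trimming the Amine Chain from Compound 3

The source may report more compounds than this note shows. Statements on the series, on what has been measured and on what is new or still open speak of the compounds shown alone.

Among the compounds with values here, compound 3 `CCOc1ccc(-c2cc3c(ncn3CCCN(C)C)c(C#N)n2)cc1C(F)(F)F` gives 27 nM in an assay on isolated protein for inhibition of cathepsin S (Homo sapiens), read by fluorescence; a higher number here means a weaker inhibitor, a lower number a stronger inhibitor; no other number so far is lower, though compound 2 `CCOc1ccc(-c2cc3c(ncn3CCN(C)C)c(C#N)n2)cc1C(F)(F)F`, at 32 nM, sits within the scatter of it, the step of a 1.2-fold lower number from compound 2 to compound 3 (0.07 log units; within the scatter) being small. Compound 1 `N#Cc1nc(-c2cccc(C(F)(F)F)c2)cc2[nH]cnc12` gives 1050 nM, a much higher number, but it differs from compound 3 in more than one place, so only its two values can be set side by side. Compound 4 `CCOc1ccc(-c2cc3c(ncn3C)c(C#N)n2)cc1C(F)(F)F` differs from compound 3 by hydrogen in place of 2-(dimethylamino)ethyl on a saturated chain carbon bound to an aromatic nitrogen. Within the data shown here, the one measured step lengthened the chain without a change beyond the scatter; removing the chain entirely has no measured counterpart. A moderately weaker result is therefore expected for compound 4, a step of a 3.3-fold higher number from compound 3 to compound 4 (0.52 log units; beyond the scatter), with an estimate of 90 nM between 30 nM and 300 nM.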

Compound 4, half-maximal inhibitory concentration: 40 nM
Compound 4: middle estimate off by 2.3-fold (0.35 log units), on the high side, within the range that was stated.
By their numbers in this assay, from the lowest: compounds 3, 2 and 4 (each within the scatter of the next); then compound 1.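

In this assay, replacing the whole amine chain leaves a 1.5-fold higher number from compound 3 to compound 4 (0.17 log units; within the scatter), and the comparison with the shorter chain gives a 1.3-fold higher number from compound 2 to compound 4 (0.10 log units; within the scatter). The earlier step only changed the chain's length, whereas these steps show that, among these three compounds, the number stays within the scatter with or without the dimethylamino group. No information here explains this result.

Still open, on these data alone, is whether a carboxylic acid or a piperidine ring on this chain would shift the number beyond the scatter. A much longer chain remains equally untested in the compounds shown.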